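An Acetyl Group on Compound 1

The source may report more compounds than this note shows. Statements on the series, on what has been measured and on what is new or still open speak of the compounds shown alone.

In a toxicity assay on SNB-19 cells (Homo sapiens) for cytotoxicity, with a stated time of 24 h (on this read-out higher numbers stand for lower toxicity in this test and lower numbers for higher toxicity in this test), compound 1 `C=C1CC[C@@H]2[C@](C)(CO)[C@H](O)CC[C@@]2(C)[C@@H]1C/C=C1/C(=O)OC[C@H]1Oc1c(Cl)cc(Cl)c2cccnc12` gives 85200 nM and sits within the scatter of compound 2 `C=C1CC[C@@H]2[C@](C)(CO)[C@H](O)CC[C@@]2(C)[C@@H]1C/C=C1/C(=O)OC[C@H]1Oc1cccnc1[N+](=O)[O-]`, which gives 67700 nM. Compound 3 `C=C1CC[C@@H]2[C@](C)(CO)[C@H](O)CC[C@@]2(C)[C@@H]1C/C=C1/C(=O)OC[C@@H]1Oc1c(Cl)cc(Cl)c2cccnc12` gives only a limit of > 100000 nM and no number. Compound 4 `C=C1CC[C@@H]2[C@](C)(COC(C)=O)[C@H](O)CC[C@@]2(C)[C@@H]1C/C=C1/C(=O)OC[C@H]1Oc1c(Cl)cc(Cl)c2cccnc12` differs from compound 1 by acetyl in place of hydrogen on an oxygen on a saturated carbon, a change from hydroxymethyl to acetoxymethyl. Within the data shown here, no measured step touches that place. The two nearest guides are changes elsewhere, a 1.3-fold lower number from compound 1 to compound 2 (0.10 log units; within the scatter) and an at least 1.1-fold higher number from compound 1 to compound 3 (0.06 log units; that floor lies within the scatter), and both lie within the scatter, the second resting on a limit. They give no reason to expect a step beyond the scatter in this assay, so the estimated step is a 1.2-fold lower number from compound 1 to compound 4 (0.09 log units; within the scatter) and no direction is firmly expected. For compound 4 the expected value is 70000 nM, with an estimated range from 30000 nM to 100000 nM.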

Compound 4, half-maximal cytotoxic concentration: 88700 nM
For compound 4 the middle estimate is 1.3-fold (0.10 log units) below the measured one; measured number inside the range.
By their numbers in this assay, from the lowest: compounds 2, 1 and 4 (each within the scatter of the next). At a limit, above all of these: compound 3.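

Putting acetyl on the oxygen of the hydroxymethyl group gives a 1.0-fold higher number from compound 1 to compound 4 (0.02 log units; within the scatter) in this assay. Among these compounds, this is the first direct reading at this place, which the earlier steps left untouched, and in this test the added acetyl brings no change beyond the scatter. Nothing available here gives a reason for this outcome.

As far as these compounds go, whether this place stays as quiet with an amine, a carboxylic acid or a longer chain in place of the acetyl remains open. So does whether acetyl would behave the same way on compound 2 or compound 3.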